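From Compound 2 to Compound 3: One Benzyl Group Changed

A few compounds are considered here, and "the series" means these few. Any claim that something is new, unique, unknown or untested is made for them only; others in the source may bear on it.

Of the compounds shown here, two have numbers so far. Compound 1 `Cc1ccc(NC(=S)NC(=O)c2ccc(OCc3ccccc3)cc2)cc1-c1nc2ccccc2[nH]1` gives 60700 nM in a functional assay on MGC-803 cells (Homo sapiens) for inhibition, read by MTT assay, with a stated time of 48 h; on this read-out higher numbers stand for weaker inhibition and lower numbers for stronger inhibition. Compound 2 `Cc1ccc(NC(=O)NC(=O)c2ccc(OCc3ccc(C(F)(F)F)cc3)cc2)cc1-c1nc2ccccc2[nH]1` gives 14900 nM in this assay, the lower of the two numbers, and its gap to compound 1 lies beyond the usual scatter. Compound 3 `Cc1ccc(NC(=O)NC(=O)c2ccc(OCc3cccc(F)c3)cc2)cc1-c1nc2ccccc2[nH]1` carries 3-fluorophenyl in place of 4-(trifluoromethyl)phenyl on a saturated chain carbon bound to an oxygen on an aromatic ring. Going by the values given here, no measured pair shows this change on its own, so the step is expected to be small, toward weaker inhibition or none beyond the scatter, namely a 1.7-fold higher number from compound 2 to compound 3 (0.22 log units; within the scatter). Compound 3 is therefore estimated at 25000 nM in this assay, between 8000 nM and 80000 nM.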

Compound 3, half-maximal inhibitory concentration: 44800 nM
Compound 3: middle estimate off by 1.8-fold (0.25 log units), on the low side, and the stated range covers the measured number.
By their numbers in this assay, from the lowest: compound 2; then compounds 3 and 1 (each within the scatter of the next).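

The group on a saturated chain carbon bound to an oxygen on an aromatic ring does affect the read-out: in this assay, 3-fluorophenyl in place of 4-(trifluoromethyl)phenyl gives a 3.0-fold higher number from compound 2 to compound 3 (0.48 log units; beyond the scatter) as a modest but real loss of inhibition. The swap changes both the substituent and where it sits on the ring, so this single step cannot separate the two. No measurement shown explains the step.

A 4-fluorophenyl group would help to separate those two changes. As far as these compounds go, how an amine or a carboxylic acid on this ring would read remains open.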